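Exchanging the tert-butyl for a methoxypropenyl chain

The source may report more compounds than this note shows. Statements on the series, on what has been measured and on what is new or still open speak of the compounds shown alone.

Compound 1 `COC(=O)/C=C/c1cccc(N(Cc2ccc(-c3cccc(C)c3)cc2)C(=O)C2CCCCC2)c1`: 109 nM
Compound 2 `COC(=O)/C=C/c1cccc(N(Cc2ccc(C(C)(C)C)cc2)C(=O)C2CCCCC2)c1`: > 1000 nM

In an assay on isolated protein with Bile acid receptor (Homo sapiens) as the target (on this read-out lower numbers stand for an effect already at smaller amounts and higher numbers for an effect only at larger amounts of compound), compound 1 gives 109 nM. For compound 2 only a limit of the assay is known, > 1000 nM, so that compound 2 stands at the limit of > 1000 nM in this assay, at which 1 of the 2 values shown sits, and its true number is not fixed. Among the compounds with values here, the single measured step, an at least 9.1-fold higher number from compound 1 to compound 2 (0.96 log units; beyond the scatter), belongs to the exchange of 3-methylphenyl for tert-butyl. Compound 3 `COC/C=C/c1ccc(CN(C(=O)C2CCCCC2)c2cccc(/C=C/C(=O)OC)c2)cc1` is obtained from compound 2 by the change (3-methoxyprop-1-en-1-yl in place of tert-butyl on an aromatic carbon). This replaces the tert-butyl with an extended, unsaturated chain carrying an oxygen, so it moves away from the group that sat at the limit, though not back to the aryl group of compound 1. He expects some recovery of activity, though with wide uncertainty because compound 2 sits at the limit of > 1000 nM in this assay, at which 1 of the 2 values shown sits. The step of an at least 1.6-fold lower number from compound 2 to compound 3 (0.22 log units; that floor lies within the scatter) is therefore expected to be modest. For compound 3 he estimates 600 nM, between 150 nM and 3000 nM.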

Compound 3, half-maximal effective concentration: 233 nM
Compound 3: middle estimate off by 2.6-fold (0.41 log units), on the high side; low and high end bracket the measured number.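

In this assay, the position para to a large group on the benzyl ring's place in the shared core also accepts a group without a ring: 3-methoxyprop-1-en-1-yl in place of tert-butyl gives an at least 4.2-fold lower number from compound 2 to compound 3 (0.63 log units; beyond the scatter). Compound 2 is known only as a limit of the assay, so the true size of that step stays unfixed: the limit of > 1000 nM in this assay, at which 1 of the 3 values shown sits. An aromatic ring at this position is thus not needed for a value in this range, although replacing the 3-methylphenyl of compound 1 with the open chain still gives a 2.1-fold higher number from compound 1 to compound 3 (0.33 log units; beyond the scatter).

As far as these compounds go, it remains open whether the gain over tert-butyl goes with the double bond, the oxygen or the chain length alone. A saturated 3-methoxypropyl chain, or a chain ending in an amine or a carboxylic acid, would begin to separate these.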